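The source may report more compounds than this note shows. Statements on the series, on what has been measured and on what is new or still open speak of the compounds shown alone.

The measured compounds are compound 1 `C=CCCC(=O)N[C@H]1[C@@H](OCCCCCCCCCCCCCCCC)O[C@H](CO)[C@@H](O)[C@@H]1O`, compound 2 `CCCCCCCC/C=C\CCCCCCCCO[C@H]1O[C@H](CO)[C@@H](O)[C@H](O)[C@H]1NC(C)=O` and compound 3 `C=CCCC(=O)N[C@H]1[C@@H](OCCCCCCCCCCCCCCCC)O[C@H](CO)[C@@H](O)[C@@H]1OS(=O)(=O)O`.

In a functional assay on U-373MG ATCC cells (Homo sapiens), read by thymidine incorporation (a lower number here means a stronger inhibitor, a higher number a weaker inhibitor), compound 1 gives > 50 uM, which is a limit of the assay rather than a number. In this assay compound 3 gives 33 uM. Compound 2 gives 4.6 uM in this assay, the lowest of the two numbers, and the gap to compound 3 lies beyond the scatter. How the core of compound 2 differs from the core of compound 1 is not broken down here.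

Compound 1 and compound 3 differ in one place: sulfo in place of hydrogen on an oxygen on a saturated carbon. That change made an at least 1.5-fold lower number from compound 1 to compound 3 (0.18 log units; that floor lies within the scatter), and the floor of this step rests on (the limit of > 50 uM in this assay, at which 1 of the 3 values shown sits).

Compound 4 `CCCCCCCC/C=C\CCCCCCCCO[C@H]1O[C@H](CO)[C@@H](O)[C@H](OS(=O)(=O)O)[C@H]1NC(C)=O` has not yet been measured in this assay. It stands to compound 2 as compound 3 stands to compound 1, the change being (sulfo in place of hydrogen on an oxygen on a saturated carbon), the same change at the same place. The measured step of an at least 1.5-fold lower number from compound 1 to compound 3 (0.18 log units; that floor lies within the scatter) gives only a floor that lies within the scatter, so only a small step is expected here as well. The step expected from compound 2 is estimated as a 1.3-fold lower number from compound 2 to compound 4 (0.12 log units; within the scatter). Compound 4 is therefore expected to give about 3.5 uM in this assay, with an estimated range from 1.2 uM to 12 uM.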

Compound 4, concentration for 50% inhibition: 9.6 uM
Compound 4: the middle estimate sits 2.7-fold (0.44 log units) below what was measured; measured number inside the range.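

In this assay, the change from hydroxy to sulfooxy did not carry over from one core to the other in the same direction: on the core of compound 2 it gave a 2.1-fold higher number from compound 2 to compound 4 (0.32 log units; beyond the scatter), a modest weakening of inhibition. Set side by side, the two steps are further apart than the scatter of two such steps would explain, so in this series the effect of the change depends on the core that carries it: the same change on two cores in this assay, an at least 1.5-fold lower number (0.18 log units; that floor lies within the scatter) from compound 1 to compound 3 and a 2.1-fold higher number (0.32 log units; beyond the scatter) from compound 2 to compound 4, at least 3.1-fold (0.49 log units) apart, beyond the scatter of two such steps. Among the compounds shown here, this rests on only one pair of steps, and it shows neither which feature of the two cores sets the steps apart nor the full size of the step on the core of compound 1, which is read against a limit of the assay: the limit of > 50 uM in this assay, at which 1 of the 4 values shown sits.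

The compounds shown leave open how another group on the same oxygen, such as a phosphate or a carboxylic acid, would read in this assay. Also open, going by these compounds, is whether a core joining the long chain of compound 1 to the amide of compound 2, or the reverse, would follow the step seen on the core of compound 1 or the one seen on the core of compound 2.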